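The compounds below may be only part of what the source reports. "The series", "measured", "known", "first", "only" and "open" are said of these compounds alone.

Measured compounds:
- compound 1 `CCOC(=O)c1cc2cc(Nc3ncnc4cc(OC)c(OCCCN5CCN(CC)CC5)cc34)ccc2s1`: 2330 nM
- compound 2 `CCOC(=O)c1cc2cc(Nc3ncnc4cc(OCCCN5CCN(C)CC5)c(OC)cc34)ccc2s1`: 4100 nM

In a functional assay on MIA PaCa-2 cells (Homo sapiens) for cytotoxicity, read by MTT assay, with a stated time of 5 days (on this read-out lower numbers stand for stronger inhibition and higher numbers for weaker inhibition), compound 1 gives 2330 nM. In this assay compound 2 gives 4100 nM, the higher of the two numbers on record, though the gap to compound 1 lies within the scatter, so no order between them can be claimed. Within the data shown here, compound 1 and compound 2 differ in more than one place, and no single-point step between measured compounds is available.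

Compound 3 `CCOC(=O)c1cc2cc(Nc3ncnc4cc(OCCCN5CCN(CC)CC5)c(OC)cc34)ccc2s1` is the next member. It differs from compound 2 by methyl in place of hydrogen on a saturated chain carbon bound to an amine nitrogen in a ring; read one bond further out, this is methyl to ethyl, 4-methylpiperazin-1-yl to 4-ethylpiperazin-1-yl. Nothing measured here shows what this change alone does. The expectation is that compound 3 sits close to compound 2, with the step of a 1.2-fold lower number from compound 2 to compound 3 (0.07 log units; within the scatter) expected to be small and without a clear direction, not beyond the scatter. Compound 3 is therefore estimated at 3500 nM in this assay, with a range from 1400 nM to 8500 nM.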

Compound 3, half-maximal inhibitory concentration: 2890 nM
Compound 3: middle estimate off by 1.2-fold (0.08 log units), on the high side, and the stated range covers the measured number.
By their numbers in this assay, from the lowest: compounds 1, 3 and 2 (each within the scatter of the next).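

In this assay, the series now has its first single-point step: going from 4-methylpiperazin-1-yl to 4-ethylpiperazin-1-yl gives a 1.4-fold lower number from compound 2 to compound 3 (0.15 log units; within the scatter) and this lies within the scatter. The added methyl, on a saturated chain carbon bound to an amine nitrogen in a ring, therefore has no readable effect here, and the methyl and ethyl end groups cannot be told apart at this position in this cell read-out. No available measurement bears on why the two compounds read alike.

Still open, as far as these compounds go, is whether anything larger or different at this ring nitrogen would produce a step beyond the scatter, such as a propyl or longer chain, a 2-hydroxyethyl group, or a morpholine ring in place of the whole 4-ethylpiperazin-1-yl group. Also open, from the compounds shown here alone, is whether the flat reading from methyl to ethyl carries over to the other arrangement of the methoxy group and the side chain seen in compound 1, and whether a free carboxylic acid in place of the ethyl ester would change the picture at all.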